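Swapping isopropyl for butyl on the shared core

The source may hold more compounds than are shown below. What is called first, only, known or untested is meant among the compounds shown, and "the series" means these compounds.

Measured in a functional assay on cells (Platelet, Homo sapiens) for inhibition; on this read-out lower numbers stand for stronger inhibition and higher numbers for weaker inhibition:
- compound 1 `CCOC(=O)c1ccc(-c2nn(Cc3cccnc3)c3ccccc23)cc1`: > 10000 nM
- compound 2 `CCOC(=O)c1ccc(-c2nn(-c3ccco3)c3ccccc23)cc1`: > 10000 nM
- compound 3 `CCOC(=O)c1ccc(-c2nn(C(C)C)c3ccccc23)cc1`: > 10000 nM

Compound 3 gives > 10000 nM, which is a limit and not a number. It shares its place with the other two compounds, at the limit of > 10000 nM in this assay, at which 3 of the 3 values shown sit. The next compound, compound 4 `CCCCn1nc(-c2ccc(C(=O)OCC)cc2)c2ccccc21`, keeps the shared core and changes one group: butyl in place of isopropyl on an aromatic nitrogen.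

Two measured steps changed this same group: a step that the two limits leave unreadable from compound 1 to compound 3 and a step that the two limits leave unreadable from compound 2 to compound 3. A third, a step that the two limits leave unreadable from compound 1 to compound 2, did so too. None of them has a readable size, so they give no direction for a new change here. Still, three different groups at this place have all ended at the same limit, and butyl is expected to do the same in this assay. The expected change is a step that the limit leaves unreadable from compound 3 to compound 4, with no real shift foreseen. The estimate for compound 4 is 14000 nM, within an expected range of 5000 nM to 40000 nM.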

Compound 4, half-maximal inhibitory concentration: > 10000 nM
Compound 4: no number, only a limit (the forecaster's own chance of this, stated with the estimate: 80%); the middle value is on the limit's open side.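

In this assay compound 4 gives > 10000 nM, a limit and not a number. Its steps from compound 1, compound 2 and compound 3 therefore cannot be read: the limit of > 10000 nM in this assay, at which 4 of the 4 values shown sit. The compounds shown leave open whether any group on this aromatic nitrogen would give a readable value.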